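A few compounds are considered here, and "the series" means these few. Any claim that something is new, unique, unknown or untested is made for them only; others in the source may bear on it.

Of the compounds shown here, three from one series have been measured in a functional assay on HL-60 cells (Homo sapiens) for inhibition, read by MTT assay, with a stated time of 72 h; on this read-out lower numbers stand for stronger inhibition and higher numbers for weaker inhibition. Compound 1, `Cc1nc(-c2ccccc2F)c(C(=O)N2CCN(c3cc(Cl)cc(Cl)c3)CC2)s1`, gives 157 nM in this assay. Compound 2, `Cc1nc(-c2cccc(F)c2)c(C(=O)N2CCN(c3cccc(Cl)c3)CC2)o1`, gives 33.7 nM in this assay. Compound 3, `Cc1nc(-c2ccccc2)c(C(=O)N2CCN(c3cccc(C(N)=O)c3)CC2)o1`, gives 71 nM in this assay. Among these three numbers, compound 3 holds the second highest: its nearest neighbour is compound 2, whose number is lower by a margin beyond the usual scatter, and the furthest is compound 1, whose number is higher, also beyond the scatter. No pair of these compounds differs in a single place, so no single-step comparison can be drawn from them.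

The next compound, compound 4, `Cc1nc(-c2ccccc2)c(C(=O)N2CCN(c3cccc(C(F)(F)F)c3)CC2)o1`, has not yet been measured. It shares the core of compound 3 and differs in one place: trifluoromethyl in place of carbamoyl on an aromatic carbon. The trifluoromethyl group brings no hydrogen-bond donor and no hydrogen-bond acceptor where the carbamoyl group brought one of each.

In this assay a step toward a lower number, of moderate size, is expected from compound 3 to compound 4, a 1.6-fold lower number from compound 3 to compound 4 (0.20 log units; within the scatter), because compound 2 carries a small group without donor or acceptor at the same kind of position and gives 33.7 nM. For compound 4 the expected value is 45 nM, with a range from 15 nM to 150 nM.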

Compound 4, half-maximal inhibitory concentration: 153 nM
Estimate against measurement, compound 4: 3.4-fold (0.53 log units) below, and the stated range ends below it.
By their numbers in this assay, from the lowest: compound 2; then compound 3; then compounds 4 and 1 (each within the scatter of the next).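

In this assay the change from carbamoyl to trifluoromethyl on this aromatic carbon gives a 2.2-fold higher number from compound 3 to compound 4 (0.33 log units; beyond the scatter) with everything else in the molecule held the same, so here carbamoyl goes with the stronger inhibition. Going by these compounds alone, this is the first comparison that isolates a single group, since the earlier compounds differed from one another in more than one place and could not separate one change from the others. It shows that, on the core of compound 3, removing the hydrogen-bond donor and acceptor of carbamoyl at this position does not bring a lower number, though nothing measured here explains why the number rises.

Still open, from the compounds shown here alone, is how a carboxylic acid, an amine or a nitrile on this carbon would compare with carbamoyl, and so whether the donor, the acceptor or neither of them goes with the lower number of compound 3. Also open, going by these compounds, is whether the same step would appear on another core, as it has been read only once, on the core of compound 3.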